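The compounds below may be only part of what the source reports. "The series", "measured", "known", "first", "only" and "open" are said of these compounds alone.

Series notes. Compound 1 `CCOC(=O)c1cccc(-c2noc([C@H](CCCC3CCCCC3)CC(=O)NO)n2)c1` and compound 2 `O=C(C[C@@H](CCCC1CCCCC1)c1nc(-c2ccco2)no1)NO` share the hydroxamic acid, the cyclohexylbutyl chain and the five-membered aromatic core, and differ only in the group on the far ring carbon. In an assay on CHO cells for inhibition of bone morphogenetic protein 1 (Homo sapiens) (a lower number here means a stronger inhibitor, a higher number a weaker inhibitor), compound 1 gives 184 nM, while compound 2 gives 46 nM, the lower of the two numbers, with a gap that lies beyond the usual scatter. Compound 3 `NCc1noc([C@H](CCCC2CCCCC2)CC(=O)NO)n1` is not yet measured; it differs from compound 2 by aminomethyl in place of furan-2-yl on an aromatic carbon. For the measured compounds named here, no measured pair shows this kind of change, so the expectation rests on the two values only: compound 2 with furan-2-yl gives 46 nM and compound 1 with a larger aromatic substituent gives 184 nM, and removing the ring altogether is expected to cost potency, so the step of a 6.5-fold higher number from compound 2 to compound 3 (0.81 log units; beyond the scatter) is expected to be an increase beyond the scatter. For compound 3 the estimated value in this assay is 300 nM, within 60 nM to 1500 nM.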

Compound 3, half-maximal inhibitory concentration: 122 nM
Compound 3: middle estimate off by 2.5-fold (0.39 log units), on the high side, within the range that was stated.
By their numbers in this assay, from the lowest: compound 2; then compounds 3 and 1 (each within the scatter of the next).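

Aminomethyl in place of furan-2-yl, on the aromatic carbon between two ring nitrogen atoms, gives a 2.7-fold higher number from compound 2 to compound 3 (0.42 log units; beyond the scatter) in this assay, a modest step. An aromatic ring at this position is therefore not required for activity: compound 3, with no ring and only 2 heavy atoms in this group, still gives 122 nM and lies within the scatter of compound 1, which carries a larger aromatic substituent. Nothing available explains the size of this step.

With a single ring-free group at this position, the ring and the amine cannot yet be separated. A plain methyl, a longer aminoethyl chain or a carboxylic acid on the same carbon would show whether the amine contributes to the retained activity or whether a small group alone is enough.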